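Turning one double bond at the assay limit

A few compounds are considered here, and "the series" means these few. Any claim that something is new, unique, unknown or untested is made for them only; others in the source may bear on it.

In an ADME assay on Vero cells (Chlorocebus sabaeus) for cytotoxicity, with a stated time of 72 h (on this read-out lower numbers stand for stronger inhibition and higher numbers for weaker inhibition), compound 1 (`CCOC(=O)c1cc(/C=C/c2ccnc3ccccc23)on1`) gives > 128000 nM, which is a limit and not a number. Compound 2 (`CCOC(=O)c1cc(CCc2ccnc3ccccc23)on1`) gives > 128000 nM, again a limit. Compound 3 (`CCOC(=O)c1cc(/C=C\c2ccc3ncccc3c2)on1`) gives > 128000 nM, also a limit, so it stands with the others on (the limit of > 128000 nM in this assay, at which 3 of the 3 values shown sit). Compound 4 (`CCOC(=O)c1cc(/C=C/c2ccc3ncccc3c2)on1`) has not yet been measured. Its relation to compound 3 is simple: the two compounds have the same atoms and bonds and differ only in configuration as drawn: 1 of 1 stereo elements differ; a double bond is drawn Z in compound 3 and E in compound 4; a double bond is drawn Z in compound 3 and E in compound 4. The expected size of a number no higher from compound 3 to compound 4 (the limit leaves the size open) in this assay is none beyond the scatter, in neither direction. That expectation rests on compound 3 giving > 128000 nM, a limit. For compound 4 the estimated value is 128000 nM, with an expected range of 50000 nM to 200000 nM.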

Compound 4, half-maximal inhibitory concentration: > 128000 nM
Compound 4 gave a limit, no number (the forecaster's own chance of this, stated with the estimate: 85%); the middle value sits exactly at the limit.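

Compound 3 gives > 128000 nM, a limit. Compound 4 gives > 128000 nM, also a limit. No step can be read between compound 3 and compound 4. Whether the configuration of the double bond changes anything in this assay stays open, and none of the compounds shown gives a number there.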